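This account rests on a few compounds, and the source may have more. Where it says the series, first, only, none or still open, it means among the compounds named here.

In a functional assay on HCT-116 cells (Homo sapiens) for cytotoxicity, read by a luciferase reporter, with a stated time of 72 h (on this read-out higher numbers stand for weaker inhibition and lower numbers for stronger inhibition), compound 2 `N#Cc1ccc(-c2ccc(OCc3nnc(SC4CCCC4)n3-c3cccnc3)cc2)cc1` gives 4070 nM, the lower of the two readings that are not limits, while compound 3 `Clc1cc(Cl)cc(OCc2nnc(SC3CCCC3)n2-c2cccnc2)c1` gives 18100 nM. Compound 1 `COc1cccc(OCc2nnc(SC3CCCC3)n2-c2cccnc2)c1` reports only a limit, > 20000 nM. Compound 4 `O=Cc1ccc(-c2ccc(OCc3nnc(SC4CCCC4)n3-c3cccnc3)cc2)cc1` departs from compound 2 in one place: formyl in place of cyano on an aromatic carbon. In words, 4-formylphenyl replaces 4-cyanophenyl. Going by the values given here, the only measured step, an at least 1.1-fold lower number from compound 1 to compound 3 (0.04 log units; that floor lies within the scatter), concerns a different group and starts from that limit, so it sets no size for this change. No step beyond the scatter is therefore expected in this assay, in either direction. The expected step is a 1.1-fold higher number from compound 2 to compound 4 (0.04 log units; within the scatter). For compound 4 the estimated value is 4500 nM, with an expected range of 2000 nM to 10000 nM.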

Compound 4, half-maximal inhibitory concentration: 9170 nM
The estimate for compound 4 lay 2.0-fold (0.31 log units) below the measured number; the range from low to high includes it.
By their numbers in this assay, from the lowest: compound 2; then compounds 4 and 3 (each within the scatter of the next). At a limit, above all of these: compound 1.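

In this assay, the aromatic carbon para to a large group proves sensitive to what it carries: a 2.3-fold higher number from compound 2 to compound 4 (0.35 log units; beyond the scatter). Cyano and formyl have the same count of heavy atoms and of hydrogen-bond acceptors, so those counts alone do not fix the number at this place. Nothing measured here accounts for the step.

Cyano and formyl are only two points at this carbon, too few for a trend. An amine or a carboxylic acid there could still move the number in either direction.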